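Swapping the furan on compound 3 for a thiophene

The source may report more compounds than this note shows. Statements on the series, on what has been measured and on what is new or still open speak of the compounds shown alone.

Compound 1 `c1ccc(-c2ccncc2)c(OCC2=NCCN2)c1`: in a functional assay for activation of Alpha-1D adrenergic receptor (Homo sapiens), read by calcium flux (a lower number here means that less compound is needed, a higher number that more compound is needed for the effect), compound 1 gives < 100000 nM, a limit of the assay.
Compound 2 `c1cnc(-c2ccccc2OCC2=NCCN2)nc1`: in this assay compound 2 gives < 100000 nM, also a limit.
Compound 3 `c1coc(-c2ccccc2OCC2=NCCN2)c1`: in this assay compound 3 gives < 100000 nM, again a limit.

Compound 3 therefore stands only at a limit, as do the other two; all three sit at the limit of < 100000 nM in this assay, at which 3 of the 3 values shown sit. The move to compound 4 `c1ccc(-c2ccsc2)c(OCC2=NCCN2)c1` is thiophen-3-yl in place of furan-2-yl on an aromatic carbon. The steps that touch compound 3, a step that the two limits leave unreadable from compound 1 to compound 3 and a step that the two limits leave unreadable from compound 2 to compound 3, give no readable size, and a step that the two limits leave unreadable from compound 1 to compound 2 is no better. No direction can be drawn from them. Compound 4 is expected to give about 10000 nM, within a range of 500 nM to 100000 nM. The expected step is a step that the limit leaves unreadable from compound 3 to compound 4.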

Compound 4, half-maximal effective concentration: 12.6 nM
Estimate against measurement, compound 4: 790-fold (2.90 log units) above; measured number below the stated range.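

The steps from compound 1, compound 2 and compound 3 to compound 4 cannot be read, as those three compounds each give only a limit: the limit of < 100000 nM in this assay, at which 3 of the 4 values shown sit.

The compounds shown leave open how large the true gaps to compound 4 are, and whether any of them is a real difference.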